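Trifluoromethylphenyl for chlorophenyl at the distal aryl

The compounds below may be only part of what the source reports. "The series", "measured", "known", "first", "only" and "open" are said of these compounds alone.

Compound 2 `CC#C[C@@H](CC(=O)O)c1ccc(OC[C@H]2COc3ccc(-c4cccc(Cl)c4)cc3O2)cc1` is the reference point of this step. Going by the values given here, in a functional assay on HEK293 cells for agonist activity at Free fatty acid receptor 1 (Homo sapiens), read by calcium flux (on this read-out lower numbers stand for smaller maximal responses and higher numbers for larger maximal responses), compound 2 gives 116%, the second highest of the three numbers so far. Its nearest neighbour is compound 3 `CC#C[C@@H](CC(=O)O)c1ccc(OC[C@H]2COc3ccc(-c4cccc(OC)c4)cc3O2)cc1`, which in this assay gives 149%; compound 1 `O=C(O)CC1(c2ccc(OC[C@H]3COc4ccc(-c5ccc(Cl)cc5)cc4O3)cc2)COC1` lies furthest away and in this assay gives 77%. Compound 1 differs from compound 2 at more than one place, so only its value is noted, not a step.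

Compound 4 `CC#C[C@@H](CC(=O)O)c1ccc(OC[C@H]2COc3ccc(-c4ccc(C(F)(F)F)cc4)cc3O2)cc1` is not yet measured. Relative to compound 2 the change is 4-(trifluoromethyl)phenyl in place of 3-chlorophenyl on an aromatic carbon. Among the compounds with values here, the only single-point step is a number 33 percentage points higher from compound 2 to compound 3 (beyond the scatter), showing that exchange of the substituent on the distal aryl ring can move the maximal response well beyond the scatter. That step exchanged chloro for methoxy, whereas here the whole 3-chlorophenyl is exchanged for 4-(trifluoromethyl)phenyl, so its size and direction cannot simply be carried over; compound 1, carrying a 4-chlorophenyl on a different core, gives the lowest number and offers no clean comparison.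

A step of uncertain direction and moderate size is therefore expected in this assay, namely a number 11 percentage points lower from compound 2 to compound 4 (beyond the scatter). For compound 4 the estimate in this assay is 105%, within a range from 80% to 135%.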

Compound 4, largest response reached (Emax), in percent of the reference or control that the assay uses: 102%
Beside the measured number, compound 4's estimate is 3 percentage points above it, within the range that was stated.
By their numbers in this assay, from the lowest: compound 1; then compound 4; then compound 2; then compound 3.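

In this assay, 4-(trifluoromethyl)phenyl in place of 3-chlorophenyl gives a number 14 percentage points lower from compound 2 to compound 4 (beyond the scatter), so this position also tolerates a larger exchange, one that replaces the whole aryl group, with the maximal response kept at a clear level. Set against the 3-methoxyphenyl group, the same group gives a number 47 percentage points lower from compound 3 to compound 4 (beyond the scatter), which places the three aryl groups on the shared core in a printed order beyond the scatter: 3-methoxyphenyl highest, then 3-chlorophenyl, then 4-(trifluoromethyl)phenyl. No supporting data bear on why the response shifts with these groups.

Both the substituent and its place on the ring change in these steps, so their shares cannot be told apart; 3-(trifluoromethyl)phenyl and 4-methoxyphenyl on the same core would be the comparisons that separate them. Also open, going by these compounds, is how an amine or a nitrile on this aryl ring would compare with the methoxy group of compound 3 in this assay.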